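This account rests on a few compounds, and the source may have more. Where it says the series, first, only, none or still open, it means among the compounds named here.

Measured in a functional assay on MCF7 cells (Homo sapiens) for antiproliferative activity, read by sulforhodamine B assay, with a stated time of 48 h; on this read-out higher numbers stand for weaker inhibition and lower numbers for stronger inhibition:

- compound 1 `COc1ccc(C2C=C(c3cc(OC)c(OC)c(OC)c3)NC(=S)N2)cc1`: 103 nM
- compound 2 `COc1cccc(C2=CC(c3ccc(Cl)cc3)NC(=S)N2)c1`: 150 nM

Within the data shown here, these are the only two numbers available so far. Compound 1 at 103 nM and compound 2 at 150 nM lie within the scatter of each other, so the two compounds cannot be told apart on this read-out.

The next compound to be tested is compound 3 `COc1cc(C2=CC(c3ccc(Cl)cc3)NC(=S)N2)cc(OC)c1OC`. It departs from compound 1 in one place, with chloro in place of methoxy on an aromatic carbon, para to a large group, so that 4-methoxyphenyl becomes 4-chlorophenyl: chloro in place of methoxy on an aromatic carbon.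

Among the measured compounds shown here, no pair of measured compounds differs in one place, so the data do not show directly what this exchange does. The two measured values give no sign of a wide spread, and no shift beyond the scatter is expected in this assay, in either direction. The estimated 1.1-fold higher number from compound 1 to compound 3 (0.03 log units; within the scatter) is accordingly small. For compound 3 the expected value is 110 nM, with an estimated range from 35 nM to 350 nM.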

Compound 3, half-maximal inhibitory concentration: 120 nM
Compound 3: the middle estimate sits 1.1-fold (0.04 log units) below what was measured; low and high end bracket the measured number.
By their numbers in this assay, from the lowest: compounds 1, 3 and 2 (each within the scatter of the next).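

Among these compounds, compound 1 and compound 3 form the first measured pair that differs in one place, and in this assay the exchange of methoxy for chloro on this aromatic carbon, para to a large group, gives a 1.2-fold higher number from compound 1 to compound 3 (0.07 log units; within the scatter). The two compounds therefore cannot be told apart on this read-out: 4-methoxyphenyl and 4-chlorophenyl are interchangeable here, at least on the core of compound 1, even though the methoxy with its two heavy atoms and one hydrogen-bond acceptor gives way to a single chlorine with no acceptor. No supporting evidence is available to explain why this pair reads alike.

This single pair cannot show whether the position tolerates exchange more widely, and an amine, a carboxylic acid or a longer chain such as butoxy on the same carbon could still move the number beyond the scatter. From the compounds shown here alone, it also remains open whether methoxy and chloro would stay equally indistinguishable in other settings, such as on a different core or in a different cell line.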